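Swapping fluoro for methoxy on a shared scaffold

The source may hold more compounds than are shown below. What is called first, only, known or untested is meant among the compounds shown, and "the series" means these compounds.

Three compounds built on one scaffold were tested in a functional assay on QGY7701 cells (Homo sapiens) for cytotoxicity, read by MTT assay, with a stated time of 24 h; on this read-out lower numbers stand for stronger inhibition and higher numbers for weaker inhibition. Compound 1 `C=CC1=C(C(=O)Nc2ccc(C)cc2)C(c2ccc(F)cc2)OC1` gives 59200 nM in this assay. Among the measured compounds shown here, compound 2 `C=CC1=C(C(=O)NCc2ccc(OC)c(OC)c2)C(c2ccc(F)cc2)OC1` gives 87300 nM in this assay, a value that sits within the usual scatter of the one for compound 1. How the cores of compound 1 and compound 2 differ is not broken down here. Compound 3 `C=CC1=C(C(=O)Nc2ccc(C)cc2)C(c2ccc(OC)cc2)OC1` reaches only a limit of the assay, > 100000 nM, and that limit is the limit of > 100000 nM in this assay, at which 1 of the 3 values shown sits. Compound 3 carries methoxy in place of fluoro on an aromatic carbon relative to compound 1, and that change gives an at least 1.6-fold higher number from compound 1 to compound 3 (0.22 log units; that floor lies within the scatter).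

Compound 4 `C=CC1=C(C(=O)NCc2ccc(OC)c(OC)c2)C(c2ccc(OC)cc2)OC1` is not yet measured; it carries methoxy in place of fluoro on an aromatic carbon relative to compound 2, the same change that turned compound 1 into compound 3. Since the earlier step was an at least 1.6-fold higher number from compound 1 to compound 3 (0.22 log units; that floor lies within the scatter), the expected step here is a 1.7-fold higher number from compound 2 to compound 4 (0.24 log units; within the scatter). On that basis compound 4 is estimated to give 150000 nM in this assay, expected to fall somewhere between 80000 nM and 300000 nM, with a fair chance that only a limit is reported.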

Compound 4, half-maximal inhibitory concentration: > 100000 nM
Compound 4: no number, only a limit; the forecaster's own chance of this, stated with the estimate: 65%; the middle value does not contradict the limit.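

In this assay compound 4 gives > 100000 nM, which is a limit of the assay and not a number. Swapping 4-fluorophenyl for 4-methoxyphenyl on this core therefore yields only a floor, an at least 1.1-fold higher number from compound 2 to compound 4 (0.05 log units; that floor lies within the scatter), so the result fits the change acting alike on both cores but does not prove it, and no true size can be given for the step. Set side by side, the two steps cannot be told apart: the same change on two cores in this assay, an at least 1.6-fold higher number (0.22 log units; that floor lies within the scatter) from compound 1 to compound 3 and an at least 1.1-fold higher number (0.05 log units; that floor lies within the scatter) from compound 2 to compound 4; the limit leaves it open whether they differ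

Much of this small set gives limits rather than numbers, so it says little about how far the swap really reaches on either core: the limit of > 100000 nM in this assay, at which 2 of the 4 values shown sit. Also open is whether an amine or a carboxylic acid in place of the fluoro or methoxy group would give a number rather than a limit on these two cores.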